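Amide series: the step from compound 2 to compound 3

The compounds below may be only part of what the source reports. "The series", "measured", "known", "first", "only" and "open" are said of these compounds alone.

Measured in a toxicity assay on THP-1 cells (Homo sapiens) for inhibition; on this read-out higher numbers stand for lower toxicity in this test and lower numbers for higher toxicity in this test:
- compound 1 `CCCC(=O)Nc1ncc(-c2ccc(OC)cc2)n1C`: > 100000 nM, a limit
- compound 2 `COc1ccc(-c2cnc(NC(=O)c3ccccc3F)n2C)cc1`: > 100000 nM, a limit

Compound 2 has no numerical value, only a limit, and the same is true of compound 1: the limit of > 100000 nM in this assay, at which 2 of the 2 values shown sit.

Compound 3 `COc1ccc(-c2cnc(NC(=O)c3ccc(C)cc3)n2C)cc1` has 4-methylphenyl in place of 2-fluorophenyl on a carbonyl carbon.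

Among the compounds with values here, the one measured step changes the group at that same place: a step that the two limits leave unreadable from compound 1 to compound 2. Its size cannot be read, since both ends are limits.

With compound 2 at > 100000 nM, a limit, no step beyond the scatter is expected in this assay, and a further limit is the likeliest report. The expected step is a number no higher from compound 2 to compound 3 (the limit leaves the size open). The value estimated for compound 3 is 100000 nM, with an expected range of 40000 nM to 200000 nM.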

Compound 3, half-maximal cytotoxic concentration: > 100000 nM
Compound 3 gave a limit, no number; the forecaster's own chance of this, stated with the estimate: 85%; the middle value lies on the limit itself.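

No new step can be read among compound 1, compound 2 and compound 3 in this assay, since each gives only a limit: the limit of > 100000 nM in this assay, at which 3 of the 3 values shown sit.

From the compounds shown here alone, whether any group on the carbonyl carbon changes toxicity in this assay stays open, with no numerical value yet to compare.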